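Cytotoxicity notes: from compound 1 to compound 4

A few compounds are considered here, and "the series" means these few. Any claim that something is new, unique, unknown or untested is made for them only; others in the source may bear on it.

Measured in an ADME assay on MT4 cells (Homo sapiens) for cytotoxicity, read by MTT assay, with a stated time of 4 days (a higher number here means that more compound is tolerated, a lower number that less compound is tolerated), as follows:
- compound 1 `CCCN(C)c1nc(Cc2c(F)cccc2F)cc(=O)[nH]1` gives 85000 nM as a number
- compound 2 `CCCN(CCC)c1nc(Cc2c(F)cccc2F)cc(=O)[nH]1` gives > 78000 nM as a limit
- compound 3 `CN1CCN(c2nc(Cc3c(F)cccc3F)cc(=O)[nH]2)CC1` gives > 78000 nM as a limit

Within the data shown here, compound 1 at 85000 nM holds the only true number in this set. Beyond it stands the limit of > 78000 nM in this assay, at which 2 of the 3 values shown sit, and so compound 1 cannot be ranked against compound 2 or compound 3.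

Compound 4 `CCCN(C)c1nc(C(C)c2c(F)cccc2F)cc(=O)[nH]1` differs from compound 1 by a single change, methyl in place of hydrogen on a saturated chain carbon bound to two aromatic carbons on a saturated chain carbon bound to two aromatic carbons.

Three measured steps exist: a step that the limit leaves unreadable from compound 1 to compound 2 then a step that the limit leaves unreadable from compound 1 to compound 3 and finally a step that the two limits leave unreadable from compound 2 to compound 3 as the last. None of them alters the saturated chain carbon bound to two aromatic carbons, and none has a readable size. They therefore give no direct guide to this change. With compound 1 at 85000 nM as the only anchor, no step beyond the scatter is expected in this assay and no direction is favoured. The expected move is a 1.1-fold lower number from compound 1 to compound 4 (0.05 log units; within the scatter) and it should stay within the scatter. Compound 4 is estimated at 75000 nM with an expected range from 35000 nM to 110000 nM and a report as a limit is quite likely.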

Compound 4, half-maximal cytotoxic concentration: > 81000 nM
Compound 4 gave a limit, no number (the forecaster's own chance of this, stated with the estimate: 60%); at least 1.0-fold (0.03 log units) between middle value and limit.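

In this assay, compound 4 gives > 81000 nM, which is a limit and not a number. The step from compound 1 to compound 4 therefore cannot be read. The compounds shown leave open whether methyl in place of hydrogen on a saturated chain carbon bound to two aromatic carbons shifts the tolerated concentration at all.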